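Substituted hydroxypiperidine amides on a shared benzoxazole core

The source may report more compounds than this note shows. Statements on the series, on what has been measured and on what is new or still open speak of the compounds shown alone.

Of the compounds shown here, three sharing one core have been measured in an assay on isolated protein for inhibition of thyroid hormone receptor beta (Homo sapiens), read by fluorescence, with a stated time of 30 min; on this read-out higher numbers stand for weaker inhibition and lower numbers for stronger inhibition. Compound 1 `COc1cc(C(=O)N2CCCC2(C)C)cc2nc(NCc3cccc(Cl)c3)oc12` gives 47 nM, and compound 2 `COc1cc(C(=O)N2CCC(C)(C)C2)cc2nc(NCc3cccc(Cl)c3)oc12` gives 40 nM, the two standing close together: a 1.2-fold lower number from compound 1 to compound 2 (0.07 log units; within the scatter). Compound 3 `COc1cc(C(=O)N2CCC(O)CC2)cc2nc(NCc3cccc(Cl)c3)oc12` gives 352 nM, the highest number of the three; the gaps to the others are a 7.5-fold higher number from compound 1 to compound 3 (0.87 log units; beyond the scatter) and an 8.8-fold higher number from compound 2 to compound 3 (0.94 log units; beyond the scatter).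

Compound 4 `COc1cc(C(=O)N2CC(C)C(O)CC2C2CC2)cc2nc(NCc3cccc(Cl)c3)oc12` is not yet measured. It differs from compound 3 at a single place: 2-cyclopropyl-4-hydroxy-5-methylpiperidin-1-yl in place of 4-hydroxypiperidin-1-yl on a carbonyl carbon. The hydroxy group on the six-membered ring is kept, while a cyclopropyl and a methyl are added to that ring.

Going by the values given here, the steps that bear on this change are those from compound 1 and compound 2 to compound 3, where the rings carrying two methyl groups gave clearly lower numbers than the ring carrying only a hydroxy group. Compound 4 carries both the hydroxy group and added carbon, so the expectation is a number somewhat lower than that of compound 3, though not reaching the dimethyl compounds: the step from compound 3 to compound 4 is estimated at a 2.9-fold lower number from compound 3 to compound 4 (0.47 log units; beyond the scatter). Compound 4 is therefore expected to give about 120 nM in this assay, within a range of 40 nM to 400 nM.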

Compound 4, half-maximal inhibitory concentration: 8 nM
Beside the measured number, compound 4's estimate is 15-fold (1.18 log units) above it; measured number below the stated range.
By their numbers in this assay, from the lowest: compound 4; then compounds 2 and 1 (each within the scatter of the next); then compound 3.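

In this assay the step from the plain hydroxy ring to the substituted one is large, a 44-fold lower number from compound 3 to compound 4 (1.64 log units; beyond the scatter), so at this position on the carbonyl carbon, the 4-hydroxypiperidin-1-yl result of compound 3 does not set the level for every ring that keeps the hydroxy group. The 2-cyclopropyl-4-hydroxy-5-methylpiperidin-1-yl group also passes both dimethyl rings, with a 5.0-fold lower number from compound 2 to compound 4 (0.70 log units; beyond the scatter) and a 5.9-fold lower number from compound 1 to compound 4 (0.77 log units; beyond the scatter), both beyond the scatter, whereas the earlier compounds had shown the hydroxy-bearing ring only with the highest number of the set. Nothing available here gives a reason for this result.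

The compounds shown do not separate the cyclopropyl from the methyl, since no compound here carries one without the other, so the share of each in the large step stays unknown. They also leave open what happens on this substituted ring if the hydroxy group is replaced by a methoxy group, an amine or a carboxylic acid, or if the cyclopropyl gives way to a cyclobutyl or a longer chain.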